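A few compounds are considered here, and "the series" means these few. Any claim that something is new, unique, unknown or untested is made for them only; others in the source may bear on it.

Working notes on the series. Within the data shown here, compound 1 `CC(C)C(Nc1nnc[nH]1)c1ccc(-c2ccc3cccc(F)c3c2)[nH]c1=O` gives 39000 nM in a physicochemical assay for solubility, measured as kinetic solubility, at pH 2 (on this read-out lower numbers stand for lower solubility and higher numbers for higher solubility), the highest of the three numbers so far, though compound 3 `CC(C)C(c1ccc(-c2ccc3cccc(F)c3c2)[nH]c1=O)N1CCNC1=O` with 31600 nM lies within the scatter of it, while compound 2 `CC(C)C(Cc1noc(=O)[nH]1)c1ccc(-c2ccc3cccc(F)c3c2)[nH]c1=O` with 18200 nM sits beyond it. The two measured steps from compound 1 are a 1.2-fold lower number from compound 1 to compound 3 (0.09 log units; within the scatter) and a 2.1-fold lower number from compound 1 to compound 2 (0.33 log units; beyond the scatter). Compound 4 `CC(C)C(/C=C1\CCNC1=O)c1ccc(-c2ccc3cccc(F)c3c2)[nH]c1=O` differs from compound 1 by a group of 7 heavy atoms (5 carbon, 1 nitrogen, 1 oxygen; one five-membered non-aromatic ring with 1 hetero atom) in place of a group of 6 heavy atoms (2 carbon, 4 nitrogen; one five-membered aromatic ring with 3 hetero atoms), on a saturated chain carbon bound to an aromatic carbon and a saturated chain carbon. Both measured replacements at this position gave lower numbers, the non-aromatic ring of compound 3 staying within the scatter and the aromatic ring of compound 2 going beyond it, so a small lowering is expected in this assay, a 1.5-fold lower number from compound 1 to compound 4 (0.18 log units; within the scatter). Compound 4 is estimated at 26000 nM, with a range of 11000 nM to 55000 nM.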

Compound 4, solubility: 23600 nM
The estimate for compound 4 lay 1.1-fold (0.04 log units) above the measured number, and the stated range covers the measured number.
By their numbers in this assay, from the lowest: compounds 2, 4, 3 and 1 (each within the scatter of the next, the first and the last beyond it).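

At this position, the entering group, with no aromatic ring and fewer hydrogen-bond donors and acceptors than (4H-1,2,4-triazol-3-yl)amino, gives a 1.7-fold lower number from compound 1 to compound 4 (0.22 log units; within the scatter) in this assay and so stays within the scatter. Among these compounds, the same holds for a 1.3-fold lower number from compound 3 to compound 4 (0.13 log units; within the scatter) and for a 1.3-fold higher number from compound 2 to compound 4 (0.11 log units; within the scatter), which places compound 4 within the scatter of both compound 1 and compound 2, the only pair beyond it. Nothing available explains these numbers.

As far as these compounds go, whether a carboxylic acid or an open-chain amine at this position would leave that band remains open.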